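The compounds below may be only part of what the source reports. "The series", "measured", "known", "first", "only" and "open" are said of these compounds alone.

The study measures compounds in a functional assay (spleen, spleen) for activation, with Mus musculus as the target; a lower number here means that less compound is needed, a higher number that more compound is needed for the effect. Compound 1, `CCCSc1nc(N)c2nc(O)n(Cc3ccccc3)c2n1`, gives 0.01 uM in this assay. Compound 3, `CCCCNc1nc(N)c2nc(O)n(Cc3ccccc3)c2n1`, gives 1 uM. Between them stands the only measured step, a 100-fold higher number from compound 1 to compound 3 (2.00 log units; beyond the scatter). Compound 2, `COc1nc2c(N)ncnc2n1Cc1ccccc1`, gives > 10 uM in this assay; this is a limit of the assay, not a number. Within the data shown here, compound 2 therefore sits at the weak end of the measured set, the one value that stays at the limit (the limit of > 10 uM in this assay, at which 1 of the 3 values shown sits), while compound 1 and compound 3 give numbers.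

The step under consideration leads from compound 2 to compound 4, `NNc1nc2c(N)ncnc2n1Cc1ccccc1`, by the change (aminoamino in place of methoxy on an aromatic carbon). Among the measured compounds shown here, no measured step bears on this change: the step from compound 1 to compound 3 concerns butylamino in place of propylsulfanyl, a different exchange on a different core, and compound 2 shares neither exchange. What can be said is that compound 2 gives only a limit, so any number for compound 4 would already mark a gain. Compound 4 is estimated at 10 uM, with a range from 1 uM to 100 uM, so the expected step of a number no higher from compound 2 to compound 4 (the limit leaves the size open) is uncertain in size and may again end at the limit.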

Compound 4, minimum effective concentration: > 10 uM
Compound 4 was reported as a limit; the forecaster's own chance of this, stated with the estimate: 50%; the middle value lies on the limit itself.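

In this assay compound 4 gives > 10 uM, which is a limit and not a number. Compound 2 stands at the same limit, so no step from compound 2 to compound 4 can be read: the limit of > 10 uM in this assay, at which 2 of the 4 values shown sit.

The compounds shown leave open whether aminoamino and methoxy differ in effect at this place at all.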